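A few compounds are considered here, and "the series" means these few. Any claim that something is new, unique, unknown or untested is made for them only; others in the source may bear on it.

Measured so far:
compound 1, `OCc1ccc(-c2nn(Cc3ccccc3F)c3ccccc23)o1`: 4900 nM; 4900 nM (2 entries)
compound 2, `Fc1ccccc1Cn1nc(-c2ccco2)c2cccnc21`: 9300 nM

For the measured compounds named here, in a functional assay (aorta) with Oryctolagus cuniculus as the target (on this read-out higher numbers stand for weaker inhibition and lower numbers for stronger inhibition), compound 2 gives 9300 nM, the only number it has; a further entry for compound 2 carries no single number. Compound 1 gives 4900 nM; 4900 nM (2 entries) in this assay, and the two values lie within the usual scatter of each other, so nothing separates compound 1 and compound 2 on these numbers. Going by the values given here, no step between compounds differing in one place has been measured.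

Compound 3, `Fc1ccccc1Cn1nc(-c2cc[nH]n2)c2cccnc21`, is not yet measured in this assay. It differs from compound 2 in one place: 1H-pyrazol-3-yl in place of furan-2-yl on an aromatic carbon. Among the compounds with values here, with no measured step of any kind to lean on, the change is expected to move the number little; the step from compound 2 to compound 3 in this assay is expected to stay within the scatter, in no firm direction, as a 1.0-fold lower number from compound 2 to compound 3 (0.01 log units; within the scatter). Compound 3 is therefore estimated to give 9000 nM in this assay, within a range from 3000 nM to 30000 nM, with a fair chance that only a limit is reported.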

Compound 3, half-maximal inhibitory concentration: 1800 nM
Compound 3: the middle estimate sits 5.0-fold (0.70 log units) above what was measured; measured number outside the range, below it.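

Replacing furan-2-yl with 1H-pyrazol-3-yl on the aromatic carbon gives a 5.2-fold lower number from compound 2 to compound 3 (0.71 log units; beyond the scatter) in this assay, and this is the only step at a single place among the compounds shown. It shows that this position, on a five-membered aromatic ring with 2 nitrogen and part of a fused or bridged system of two rings, is not indifferent to which five-membered aromatic ring it carries, even though both groups have the same number of heavy atoms and no net charge. The two groups differ in their hetero atoms and in the hydrogen-bond donor that only 1H-pyrazol-3-yl has, but no measurement shown links either difference to the lower number.

The compounds shown leave open which of those two differences matters, a question that a methyl group on the pyrazole nitrogen or an imidazole ring at the same carbon could help to separate. Also open, from the compounds shown here alone, are how thiophene-2-yl, a pyridine ring or a carboxylic acid would fare at this position, and whether the step carries over to the core of compound 1.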